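The source may report more compounds than this note shows. Statements on the series, on what has been measured and on what is new or still open speak of the compounds shown alone.

In a functional assay on MCF7 cells (Homo sapiens) for cytotoxicity, read by MTT assay, with a stated time of 48 h (on this read-out lower numbers stand for stronger inhibition and higher numbers for weaker inhibition), compound 3 `Nc1cccc(-c2cnc3[nH]cc(-c4ccncc4)c3c2)c1` gives 2300 nM, the lowest of the three numbers recorded so far; compound 1 `Nc1cc(NS(=O)(=O)c2ccccc2)cc(-c2cnc3[nH]cc(-c4ccncc4)c3c2)c1` gives 8800 nM and compound 2 `Cc1ccc(S(=O)(=O)Nc2cc(N)cc(-c3cnc4[nH]cc(-c5ccncc5)c4c3)c2)cc1` gives 10400 nM. The relevant steps are a 3.8-fold lower number from compound 1 to compound 3 (0.58 log units; beyond the scatter) and a 4.5-fold lower number from compound 2 to compound 3 (0.66 log units; beyond the scatter), whereas a 1.2-fold higher number from compound 1 to compound 2 (0.07 log units; within the scatter). Compound 4 `CS(=O)(=O)Nc1cc(N)cc(-c2cnc3[nH]cc(-c4ccncc4)c3c2)c1` carries the change (methanesulfonamido in place of hydrogen on an aromatic carbon). Both measured steps show that a (phenylsulfonyl)amino or ((4-methylphenyl)sulfonyl)amino group on that aromatic carbon raises the number beyond the scatter, and exchanging one for the other did nothing; the methanesulfonamido group keeps the sulfonamide but drops the aromatic ring, so an upward step of similar or slightly smaller size is expected, namely a 2.6-fold higher number from compound 3 to compound 4 (0.42 log units; beyond the scatter). Compound 4 is accordingly estimated at 6000 nM, with a range from 2500 nM to 14000 nM.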

Compound 4, half-maximal inhibitory concentration: > 30000 nM
Compound 4: a limit, no number; the forecaster's own chance of this, stated with the estimate: 5%; middle value at least 5.0-fold (0.69 log units) from the limit.
By their numbers in this assay, from the lowest: compound 3; then compounds 1 and 2 (each within the scatter of the next). At a limit, above all of these: compound 4.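

Compound 4 stands only as a limit of the assay, not a number: the limit of > 30000 nM in this assay, at which 1 of the 4 values shown sits. On this aromatic carbon, meta to an amino group, methanesulfonamido gives an at least 13-fold higher number from compound 3 to compound 4 (1.11 log units; beyond the scatter), so the upward shift seen with the aryl sulfonamides does not depend on an aromatic ring on the sulfonyl sulfur. Methyl on that sulfur sits further from compound 3 than either aryl group, with an at least 3.4-fold higher number from compound 1 to compound 4 (0.53 log units; beyond the scatter) and an at least 2.8-fold higher number from compound 2 to compound 4 (0.46 log units; beyond the scatter).

On these data alone, how far compound 4 lies past its limit stays open. Also open, as far as these compounds go, is where an amide at this carbon, or a longer chain on the sulfonyl sulfur, would fall.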